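This account rests on a few compounds, and the source may have more. Where it says the series, first, only, none or still open, it means among the compounds named here.

Compound 1 `CCOCCOC(=O)Nc1cc2nc(C3CCCCC3)[nH]c2cc1N(C)C` was examined in an ADME assay on Vero cells (Chlorocebus sabaeus) for cytotoxicity, read by resazurin assay, with a stated time of 3 days; a higher number here means a weaker inhibitor, a lower number a stronger inhibitor. There compound 1 reaches only the limit of the test, > 100 ug/mL. Compound 2 `O=C(Nc1cc2nc(C3CCCCC3)[nH]c2cc1N1CCCC1)c1ccc(Br)cc1` likewise reports a limit, > 100 ug/mL. Compound 3 `O=C(CCc1ccccc1)Nc1cc2nc(C3CCCCC3)[nH]c2cc1N1CCCC1` also reports a limit, > 100 ug/mL. Among the measured compounds shown here, the single change between measured compounds, a step that the two limits leave unreadable from compound 2 to compound 3, cannot be sized because of the limit of > 100 ug/mL in this assay, at which 3 of the 3 values shown sit. Compound 4 `CN(C)c1cc2[nH]c(C3CCCCC3)nc2cc1NC(=O)c1ccc(OC(F)F)cc1` differs from compound 1 by 4-(difluoromethoxy)phenyl in place of 2-ethoxyethoxy on a carbonyl carbon. For the measured compounds named here, no measured step bears directly on this change, and the one measured step is unreadable. Compound 4 is therefore expected to sit at the limit again, with an estimate of 100 ug/mL, between 50 ug/mL and 200 ug/mL. The step of a number no higher from compound 1 to compound 4 (the limit leaves the size open) is expected to be none beyond the scatter.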

Compound 4, half-maximal inhibitory concentration: > 100 ug/mL
Compound 4: only a limit was reported; the forecaster's own chance of this, stated with the estimate: 80%; the middle value lies on the limit itself.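

Among the compounds shown here, compound 1 and compound 4 both report only a limit in this assay, so no step between them can be read: the limit of > 100 ug/mL in this assay, at which 4 of the 4 values shown sit. The compounds shown leave open what a change on the carbonyl carbon does to the half-maximal inhibitory concentration in this assay.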